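This account rests on a few compounds, and the source may have more. Where it says the series, first, only, none or still open, it means among the compounds named here.

Among the compounds with values here, in a functional assay on A-375 cells (Homo sapiens) for inhibition, read by MTT assay, with a stated time of 4 days (on this read-out lower numbers stand for stronger inhibition and higher numbers for weaker inhibition), compound 1 `CN1C[C@@H]2C[C@H]1CN2c1ccc(-c2ccnc3c(-c4cccc5[nH]ncc45)c(-c4ccncc4)nn23)cc1` gives 202 nM, and compound 2 `c1cc(-c2c(-c3ccncc3)nn3c(-c4ccc(CN5C[C@@H]6C[C@H]5CO6)cc4)ccnc23)c2cn[nH]c2c1` gives 945 nM, the higher of the two numbers so far. Compound 3 `c1cc(-c2c(-c3ccncc3)nn3c(-c4ccc(CN5C[C@@H]6C[C@H]5CN6)cc4)ccnc23)c2cn[nH]c2c1` differs from compound 2 by one change: a group of 7 heavy atoms (5 carbon, 2 nitrogen; 2 five-membered non-aromatic rings with 1 hetero atom each) in place of a group of 7 heavy atoms (5 carbon, 1 nitrogen, 1 oxygen; 2 five-membered non-aromatic rings with 1 hetero atom each), on a saturated chain carbon bound to an aromatic carbon. Within the data shown here, one measured step bears on this, a 4.7-fold higher number from compound 1 to compound 2 (0.67 log units; beyond the scatter), where a group with two nitrogens gave way to one with nitrogen and oxygen. That step sits on an aromatic carbon, so it is only a loose guide, but the reverse exchange should lower the number somewhat. The expected change is a 2.4-fold lower number from compound 2 to compound 3 (0.37 log units; beyond the scatter). Compound 3 is estimated at 400 nM, with an expected range of 130 nM to 1200 nM.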

Compound 3, half-maximal inhibitory concentration: 9480 nM
For compound 3 the middle estimate is 24-fold (1.37 log units) below the measured one, and the stated range ends below it.
By their numbers in this assay, from the lowest: compound 1; then compound 2; then compound 3.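

On the saturated chain carbon bound to an aromatic carbon, replacing the group with nitrogen and oxygen by the group with two nitrogens and one hydrogen-bond donor brings a 10-fold higher number from compound 2 to compound 3 (1.00 log units; beyond the scatter) in this assay, so the exchange here does not mirror the step seen on the aromatic carbon. Matching heavy-atom counts alone do not set the number either, as a 47-fold higher number from compound 1 to compound 3 (1.67 log units; beyond the scatter) shows. No measurement at hand explains these steps. Still open, from the compounds shown here alone, is how a methyl group on the new ring nitrogen would read at this place, and whether the hydrogen-bond donor counted there goes with the higher number.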